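Ureido in Place of Carbamoyl: An Expected Small Step

This account rests on a few compounds, and the source may have more. Where it says the series, first, only, none or still open, it means among the compounds named here.

Compound 1 `CN(C)/N=N/c1ccc(C(N)=O)cc1` gives 3.51 in a functional assay on L1210 cells (Mus musculus) for antiproliferative activity; a higher number here means a more potent compound, by a factor of ten per unit of this negative logarithm, a lower number a less potent compound.
Compound 2 `CC(C)N(C)/N=N/c1ccc(C(N)=O)cc1` gives 3.17 in this assay.
Compound 3 `C=CCN(C)/N=N/c1ccc(C(N)=O)cc1` gives 3.38 in this assay.

Compound 1 holds the highest of the three numbers; compound 3 sits closest to it, with a number 0.13 log units lower from compound 1 to compound 3 (within the scatter), while compound 2 lies furthest away, with a number 0.34 log units lower from compound 1 to compound 2 (beyond the scatter). Compound 4 `CN(C)/N=N/c1ccc(NC(N)=O)cc1` differs from compound 1 in a single group: ureido in place of carbamoyl on an aromatic carbon. Within the data shown here, none of the measured steps touches this group; all three concern what sits on the amine nitrogen, and even the largest of them is modest. With no direct guide, only a small expected step, a number 0.11 log units lower from compound 1 to compound 4 (within the scatter), can be drawn, carrying wide uncertainty. Compound 4 is therefore estimated at 3.4, between 2.9 and 3.9.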

Compound 4, logarithm of the reciprocal of the active concentration, log(1/C) in the L1210 assay: 3.97
Beside the measured number, compound 4's estimate is 0.57 log units below it; the whole stated range lies below it.
By their numbers in the L1210 assay, from the lowest: compounds 2, 3 and 1 (each within the scatter of the next, the first and the last beyond it); then compound 4.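

Changing the group on this aromatic carbon can move potency: in the L1210 assay, ureido in place of carbamoyl gives a number 0.46 log units higher from compound 1 to compound 4 (beyond the scatter), the only rise beyond the scatter among the steps shown. In a physicochemical assay for lipophilicity, measured as octanol-water partition (on this read-out lower numbers stand for lower lipophilicity and higher numbers for higher lipophilicity), compound 1 gives 1.2 and compound 4 gives 1.25, two values within the scatter of each other, so this read-out does not separate them.

Nothing shown accounts for the rise in potency. Open too, on these data alone, is how an amine or a carboxylic acid on this aromatic carbon would compare, and whether ureido brings the same rise with isopropyl or allyl on the amine nitrogen.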